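This account rests on a few compounds, and the source may have more. Where it says the series, first, only, none or still open, it means among the compounds named here.

Within the data shown here, compound 1 `CCn1c(-c2cnc(C)nc2)nc2c(O[C@H]3CCN(C(=O)C4CCC4)C3)ncnc21` is the weakest survivor of the three compounds measured so far in an ADME assay (Canis lupus familiaris, strain Beagle) for metabolic stability; a higher number here means that the compound lasts longer, a lower number that the compound disappears faster: compound 1 gives 1.1 h. Compound 3 `CCn1c(-c2ccc(C(F)(F)F)nc2)nc2c(O[C@H]3CCN(C(=O)C4CCOC4)C3)ncnc21` gives 3.6 h in this assay, and compound 2 `CCn1c(-c2cnc(C)nc2)nc2c(N[C@H]3CCN(C(=O)[C@H]4C[C@@H](OC)C4)C3)ncnc21` gives 4.3 h, both beyond the scatter above compound 1. Compound 4 `CCn1c(-c2cnc(C)nc2)nc2c(O[C@H]3CCN(C(=O)[C@H]4C[C@@H](OC)C4)C3)ncnc21` has not yet been measured. It differs from compound 1 in one place: methoxy in place of hydrogen on a saturated ring carbon. Among the measured compounds shown here, compound 2 also carries a 3-methoxycyclobutyl group, but it differs from compound 1 elsewhere as well, so its value shows only that such a compound can last longer. For compound 4 the step from compound 1 is expected to be a 2.0-fold higher number from compound 1 to compound 4 (0.30 log units; within the scatter), a gain somewhat beyond the scatter. Compound 4 is estimated at 2.2 h, within 1 h to 4.5 h.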

Compound 4, half-life: 3.6 h
Compound 4: the middle estimate sits 1.6-fold (0.21 log units) below what was measured; measured number inside the range.
By their numbers in this assay, from the lowest: compound 1; then compounds 3, 4 and 2 (each within the scatter of the next).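

Going from cyclobutyl to 3-methoxycyclobutyl gives a 3.3-fold higher number from compound 1 to compound 4 (0.51 log units; beyond the scatter) in this assay. Among these compounds, this is the first pair of compounds that differ in only one place, so this longer survival can be tied to this single change on the four-membered ring, not to differences elsewhere in the molecule. No measurement shown explains how the methoxy group produces this rise. Still open, from the compounds shown here alone, is whether methoxy itself matters, since a hydroxy group, a fluorine atom or a longer ethoxy chain on that ring carbon could give a different number.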